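Ethyl for fluoro on the sulfonamide aryl of compound 2

The source may report more compounds than this note shows. Statements on the series, on what has been measured and on what is new or still open speak of the compounds shown alone.

Compound 1 `CC(=O)c1ccc(OCCCN2CC[C@H](NC(=O)[C@@H](N)CO)C2)cc1`: 22000 nM
Compound 2 `O=C(c1ccc(OCCCN2CC[C@H](NS(=O)(=O)c3ccc(F)cc3)C2)cc1)C1CC1`: 500 nM
Compound 3 `O=C(N[C@H]1CCN(CCCOc2ccc(C(=O)C3CC3)cc2)C1)c1csc(-c2cccnc2)n1`: 4000 nM

Of the compounds shown here, three sharing the same core have been measured in an assay on isolated protein for binding affinity to histamine H2 receptor (Homo sapiens); a higher number here means a weaker inhibitor, a lower number a stronger inhibitor. Compound 2 gives 500 nM, the lowest of the three numbers. Compound 3 gives 4000 nM, a higher number that lies beyond the scatter of the method, and compound 1 gives 22000 nM, the furthest of the three from compound 2. For the measured compounds named here, compound 2 therefore stands as the strongest binder among the compounds measured so far.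

Compound 4 `CCc1ccc(S(=O)(=O)N[C@H]2CCN(CCCOc3ccc(C(=O)C4CC4)cc3)C2)cc1` has not yet been measured. It differs from compound 2 in one place: ethyl in place of fluoro on an aromatic carbon. Cut one bond further out, the change reads 4-fluorophenyl to 4-ethylphenyl. Going by the values given here, no pair of measured compounds that differ in a single place is available, so the size of this step cannot be read from the data. The step from compound 2 to compound 4 is expected to be small, a 1.3-fold lower number from compound 2 to compound 4 (0.10 log units; within the scatter), and not beyond the scatter. Compound 4 is estimated to give 400 nM, with a range from 150 nM to 1500 nM.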

Compound 4, inhibition constant: 330 nM
For compound 4 the middle estimate is 1.2-fold (0.08 log units) above the measured one, and the stated range covers the measured number.
By their numbers in this assay, from the lowest: compounds 4 and 2 (each within the scatter of the next); then compound 3; then compound 1.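

In this assay the change from 4-fluorophenyl to 4-ethylphenyl gives a 1.5-fold lower number from compound 2 to compound 4 (0.18 log units; within the scatter) and is the first step shown that alters a single place. On this aromatic carbon, para to a large group, ethyl and fluoro therefore cannot be told apart, so the binding seen with compound 2 does not depend on fluoro specifically among these two groups. Nothing available bears on why the two groups read alike.

The compounds shown leave open how an amine, a carboxylic acid or a longer chain on this same aromatic carbon would read in this assay, and so how far this tolerance extends. They also leave open whether a hydroxyl or a methoxy group there would stay within the scatter of compound 2.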